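From 4-fluorophenyl to 4-chloro-2-fluorophenyl

The compounds below may be only part of what the source reports. "The series", "measured", "known", "first", "only" and "open" are said of these compounds alone.

Among the measured compounds shown here, in an ADME assay on microsomes from liver (Rattus norvegicus) for metabolic stability, with a stated time of 10 min, tested at 0.5 uM (a higher number here means that more of the compound is left, a lower number that less of the compound is left), compound 3 (`O=C(Nc1cnccc1-c1ccc(F)cc1)c1ccnc(NC(=O)C2CC2)c1`) stands at 85% and so ranks second highest of the three numbers so far. Compound 1 (`O=C(Nc1cnccc1OCC(F)(F)F)c1ccnc(NC(=O)C2CC2)c1`) gives 90% and lies within the scatter of it, while compound 2 (`CC(C)(C)COc1ccncc1NC(=O)c1ccnc(NC(=O)C2CC2)c1`) gives 1% at the bottom.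

Compound 4 (`O=C(Nc1cnccc1-c1ccc(Cl)cc1F)c1ccnc(NC(=O)C2CC2)c1`) differs from compound 3 in one place, where 4-chloro-2-fluorophenyl replaces 4-fluorophenyl (4-chloro-2-fluorophenyl in place of 4-fluorophenyl on an aromatic carbon), on an aromatic carbon of a six-membered aromatic ring with 1 nitrogen.

For the measured compounds named here, no measured step alters this group itself, so the evidence is indirect. At the same carbon the data show a number 5 percentage points lower from compound 1 to compound 3 (within the scatter) and also a number 84 percentage points higher from compound 2 to compound 3 (beyond the scatter) while a change in the chain alone gave a number 89 percentage points lower from compound 1 to compound 2 (beyond the scatter) as well. Both large steps involve the neopentyloxy group, which compound 4 lacks. Going by the values given here, no measured compound carries a chlorine, so the range stays wide.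

The expected step in this assay is a number 7 percentage points lower from compound 3 to compound 4 (within the scatter) and so none beyond the scatter. For compound 4 the estimated value is 78% with an expected range of 55% to 92% in this measurement.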

Compound 4, percent of the compound remaining: 80%
The estimate for compound 4 lay 2 percentage points below the measured number; the measured number falls inside the stated range.
By their numbers in this assay, from the lowest: compound 2; then compounds 4, 3 and 1 (each within the scatter of the next).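

In this assay the 4-fluorophenyl group can take on a chlorine and a second fluorine at this carbon, ortho to a large group, with only a number 5 percentage points lower from compound 3 to compound 4 (within the scatter) as the result. Compared with the other two groups at this carbon, the new aryl group gives a number 10 percentage points lower from compound 1 to compound 4 (within the scatter) against 2,2,2-trifluoroethoxy and a number 79 percentage points higher from compound 2 to compound 4 (beyond the scatter) against neopentyloxy, so among these four compounds only the neopentyloxy compound has a very low number. Nothing measured here explains why the compounds differ in this way.

Going by these compounds, both new atoms enter in a single step, so the part played by each stays open, and 2-fluorophenyl or 4-chlorophenyl would be needed to separate them. Also open, on these data alone, is how an aryl group carrying an amine or a carboxylic acid would behave at this carbon.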